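Aryl change on the ring nitrogen, compound 3 to 4

A few compounds are considered here, and "the series" means these few. Any claim that something is new, unique, unknown or untested is made for them only; others in the source may bear on it.

Three compounds of the series have numbers in an assay on CHO-K1 cells for antagonist activity at transient receptor potential cation channel subfamily V member 1 (Homo sapiens), read by FLIPR and calcium flux, with a stated time of 6 min; a lower number here means a stronger inhibitor, a higher number a weaker inhibitor. Compound 1 `Cn1ncc2c(NC(=O)NCc3cc(C(F)(F)F)nn3-c3cccc(Cl)c3)cccc21` gives 2.3 nM. Compound 2 `Cn1ncc2c(NC(=O)NCc3cc(C(C)(C)C)nn3-c3cccc(Cl)c3)cccc21` gives 0.4 nM. Compound 3 `O=C(NCc1cc(C(F)(F)F)nn1-c1cccc(C(F)(F)F)c1)Nc1cccc2[nH]ncc12` gives 1.3 nM. For the measured compounds named here, the one step within a single position is a 5.8-fold lower number from compound 1 to compound 2 (0.76 log units; beyond the scatter). Compound 3 stands second highest of the three numbers: its gap to compound 1 is within the scatter, its gap to compound 2 is beyond it.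

Compound 4 `Cc1ccc(-n2nc(C(F)(F)F)cc2CNC(=O)Nc2cccc3[nH]ncc23)cc1C` differs from compound 3 by 3,4-dimethylphenyl in place of 3-(trifluoromethyl)phenyl on an aromatic nitrogen. Going by the values given here, the only measured step, from compound 1 to compound 2, concerns the group on an aromatic carbon of the same five-membered ring, not the aryl on the ring nitrogen, so no measured step bears on this change directly. Among the compounds with values here, the three numbers so far sit close together despite varied substituents, and nothing in the data points to a direction for an aryl swap at this place. The expectation for compound 4 is therefore a 1.2-fold higher number from compound 3 to compound 4 (0.06 log units; within the scatter), a step not beyond the scatter. Compound 4 is estimated at 1.5 nM in this assay, with a range from 0.4 nM to 6 nM.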

Compound 4, inhibition constant: 2.8 nM
Compound 4: middle estimate off by 1.9-fold (0.27 log units), on the low side; the range from low to high includes it.
By their numbers in this assay, from the lowest: compound 2; then compounds 3, 1 and 4 (each within the scatter of the next, the first and the last beyond it).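

In this assay the aryl on the aromatic nitrogen now has a measured step of its own, and the exchange of 3-(trifluoromethyl)phenyl for 3,4-dimethylphenyl gives a 2.2-fold higher number from compound 3 to compound 4 (0.33 log units; beyond the scatter). This is modest but beyond the scatter, so this position responds to the aryl change, and the series keeps a number of 2.8 nM for compound 4 with no fluorine on this aryl group. The earlier step concerned only the group on an aromatic carbon of the same five-membered ring, and no measurement at hand explains the new step.

This single pair cannot separate the loss of trifluoromethyl from the arrival of the two methyl groups, so a phenyl carrying just one methyl group, or an unsubstituted phenyl, remains the open comparison. Also open, from the compounds shown here alone, are how this position responds to an aryl group bearing an amine or a carboxylic acid, and whether the same aryl exchange gives a similar step when tert-butyl replaces trifluoromethyl on the aromatic carbon.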